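The source may report more compounds than this note shows. Statements on the series, on what has been measured and on what is new or still open speak of the compounds shown alone.

Within the data shown here, compound 3 `CCOC(=O)Nc1cccc2c1CN(C)CC2c1ccc(Cl)cc1` is the starting point of this account, and in a functional assay on the whole organism for inhibition of sodium-dependent dopamine transporter (Mus musculus) (a higher number here means that more compound is needed for the effect, a lower number that less compound is needed), compound 3 gives 21 mg/kg, the highest of the three numbers measured so far. Its nearest neighbour on that scale is compound 1 `CN1Cc2c(N)cccc2C(c2ccc(F)cc2)C1`, which in this assay gives 7.5 mg/kg. The furthest is compound 2 `CCOC(=O)Nc1cccc2c1CN(C)CC2c1ccccc1`, which in this assay gives 2.5 mg/kg. Among the measured compounds shown here, compound 2 and compound 3 share everything except one substituent on the six-membered aromatic ring of carbon only, and the measured step of an 8.4-fold higher number from compound 2 to compound 3 (0.92 log units; beyond the scatter) is the only single change in this set, so adding the chloro group pushed the dose upward.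

Compound 4 `CCOC(=O)Nc1cccc2c1CN(C)CC2c1ccc(F)cc1` is now to be tested in this assay. The change from compound 3 to compound 4 is fluoro in place of chloro on an aromatic carbon. For the measured compounds named here, no measured pair shows a chloro-to-fluoro exchange directly, so the expectation rests on two things: the upward step an 8.4-fold higher number from compound 2 to compound 3 (0.92 log units; beyond the scatter) when chloro entered, and the fact that compound 1, carrying fluoro on the same ring though differing elsewhere, gives 7.5 mg/kg. On this basis compound 4 is expected to come out below compound 3 but not as low as compound 2, a step estimated as a 3.0-fold lower number from compound 3 to compound 4 (0.48 log units; beyond the scatter). Compound 4 is therefore estimated at 7 mg/kg in this assay, with an expected range from 2.5 mg/kg to 20 mg/kg.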

Compound 4, dose for half-maximal effect: 4.6 mg/kg
The estimate for compound 4 lay 1.5-fold (0.18 log units) above the measured number; measured number inside the range.
By their numbers in this assay, from the lowest: compounds 2, 4 and 1 (each within the scatter of the next, the first and the last beyond it); then compound 3.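

In this assay the exchange from 4-chlorophenyl to 4-fluorophenyl gives a 4.6-fold lower number from compound 3 to compound 4 (0.66 log units; beyond the scatter) at this place, so the read-out here depends on which halogen is present and not merely on whether one is present. Chloro in place of hydrogen gave an 8.4-fold higher number from compound 2 to compound 3 (0.92 log units; beyond the scatter) beyond the scatter, whereas fluoro in place of hydrogen gives a 1.8-fold higher number from compound 2 to compound 4 (0.26 log units; within the scatter) and so cannot be told apart from hydrogen in this assay, which means that the upward step belongs to chloro and is not shared by fluoro. Among these compounds, with fluoro in this place, ethoxycarbonyl in place of hydrogen on the nitrogen on the aromatic ring gives a 1.6-fold lower number from compound 1 to compound 4 (0.21 log units; within the scatter) and so makes no difference that can be read, which is a point that the earlier compounds could not show.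

Nothing available bears on why chloro and fluoro part here. From the compounds shown here alone, it remains open whether bromo, methyl or methoxy at this place would follow chloro or fluoro, and whether an acetyl group or a longer chain on that nitrogen would also leave the number within the scatter.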